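This account rests on a few compounds, and the source may have more. Where it says the series, first, only, none or still open, it means among the compounds named here.

Compound 1 `COc1ccc(S(=O)(=O)c2cnc3ccc(C)cc3c2N2CCC(C)CC2)cc1Cl` stands at the top of the three measured compounds in an assay on isolated protein for displacement of a labelled ligand from metabotropic glutamate receptor 5 (Homo sapiens), with a stated time of 60 min, tested at 1 uM (a lower number here means less inhibition, a higher number more inhibition at the concentration tested (going by the name of the read-out)), where compound 1 gives 93%. Compound 3 `Cc1ccc(S(=O)(=O)c2cnc3ccc(Cl)cc3c2N2CCC(C)CC2)cc1F` comes nearest, and in this assay compound 3 gives 68%, a gap beyond the usual scatter. Compound 2 `COc1ccc(S(=O)(=O)c2cnc3ccc(OC)cc3c2N2CCC(C)CC2)cc1` lies furthest away, and in this assay compound 2 gives 41%, again well beyond the scatter. Neither of these two differs from compound 1 in one place only, so their numbers are simply the values they show.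

Compound 4 `Cc1ccc2ncc(S(=O)(=O)c3cc(Cl)cc(Cl)c3)c(N3CCC(C)CC3)c2c1` has not yet been measured. It differs from compound 1 as follows: 3,5-dichlorophenyl in place of 3-chloro-4-methoxyphenyl on a sulfonyl sulfur. The sulfonyl-bound ring is varied here while the core keeps the methyl of compound 1. The three measured compounds show that this ring can move the read-out a long way, but none of them carries a ring without a hydrogen-bond acceptor, so no direct comparison exists. A modest step downward is expected in this assay, of a size that may stay within the scatter, given that compound 1 shows 93%. The estimated step is a number 13 percentage points lower from compound 1 to compound 4 (beyond the scatter). Compound 4 is expected to give 80%, within a range from 55% to 96%.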

Compound 4, a percentage reported as inhibition, at one concentration (the size of the read-out at that concentration, not a potency): 75%
The estimate for compound 4 lay 5 percentage points above the measured number, within the range that was stated.
By their numbers in this assay, from the lowest: compound 2; then compounds 3 and 4 (each within the scatter of the next); then compound 1.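

Among these compounds, with the core of compound 1 held fixed, this pair gives the first comparison that isolates the ring on the sulfonyl sulfur: in this assay the exchange gives a number 18 percentage points lower from compound 1 to compound 4 (beyond the scatter). The 3,5-dichlorophenyl ring, with 0 hydrogen-bond acceptors against 1 in 3-chloro-4-methoxyphenyl, therefore costs measurable inhibition at this position, yet compound 4 still gives 75%. No measurement shown here bears on the reason for this step.

The compounds shown leave open whether an amine or a carboxylic acid on this ring would retain inhibition in this assay. They also leave open whether the same exchange would give a step of similar size on a core carrying the methoxy group of compound 2 or the chlorine of compound 3.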